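Removing the Methoxy Group from Compound 2

The compounds below may be only part of what the source reports. "The series", "measured", "known", "first", "only" and "open" are said of these compounds alone.

In an ADME assay on THP-1 cells (Homo sapiens) for cytotoxicity, read by MTT assay, with a stated time of 72 h (a higher number here means that more compound is tolerated, a lower number that less compound is tolerated), compound 1 (`C=C(C(=O)OCC)C(OCCC(=O)OCC)c1ccc(Cl)cc1Cl`) gives > 100 uM, which is a limit of the assay and not a number. Compound 2 (`C=C(C(=O)OCC)C(OC)c1ccccc1Cl`) gives > 100 uM, and this too is only a limit. Compound 3 (`C=C(Cc1ccccc1Cl)C(=O)OCC`) has hydrogen in place of methoxy on a saturated chain carbon bound to an aromatic carbon and a double-bonded chain carbon. For the measured compounds named here, the only evidence is the limit of > 100 uM in this assay, at which 2 of the 2 values shown sit, so no change beyond the scatter is expected in either direction. The estimated step, a number no higher from compound 2 to compound 3 (the limit leaves the size open), is expected to stay within the scatter. The estimate for compound 3 is 100 uM, with an expected range from 50 uM to 200 uM.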

Compound 3, half-maximal toxic concentration: > 100 uM
Compound 3: a limit, no number (the forecaster's own chance of this, stated with the estimate: 75%); the middle value sits exactly at the limit.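

For the compounds shown here, compound 2 and compound 3 both stand at a limit, not a number, and no step between them can be read in this assay. The compounds shown leave open whether hydrogen in place of methoxy changes the toxic concentration at all.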